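From 4-methylphenyl to 4-iodophenyl in compound 3

The source may hold more compounds than are shown below. What is called first, only, known or untested is meant among the compounds shown, and "the series" means these compounds.

- compound 1 `O=C1[C@H]2N=NN(Cc3nc(-c4ccccc4)no3)[C@H]2C(=O)N1c1ccccc1`: 47.3 ug/mL
- compound 2 `Cc1ccc(-c2noc(CN3N=N[C@@H]4C(=O)N(c5ccccc5)C(=O)[C@@H]43)n2)cc1`: 15.2 ug/mL

Compound 2 holds the lower of the two numbers in an ADME assay on L6 cells (Rattus norvegicus) for cytotoxicity, read by resazurin assay, with a stated time of 72 h; on this read-out lower numbers stand for stronger inhibition and higher numbers for weaker inhibition. Compound 3 `O=C1[C@H]2N=NN(Cc3nc(-c4ccc(I)cc4)no3)[C@H]2C(=O)N1c1ccccc1` carries iodo in place of methyl on an aromatic carbon, para to a large group: iodo in place of methyl on an aromatic carbon. For the measured compounds named here, only one measured step bears on this change: a 3.1-fold lower number from compound 1 to compound 2 (0.49 log units; beyond the scatter), a modest step with methyl in place of hydrogen on an aromatic carbon. Going by the values given here, no measured compound carries iodo, so the direction is open and no shift beyond the scatter is expected in this assay. The estimated change is a 1.1-fold lower number from compound 2 to compound 3 (0.04 log units; within the scatter). For compound 3 the expected value is 14 ug/mL, with an estimated range of 5 ug/mL to 40 ug/mL.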

Compound 3, half-maximal inhibitory concentration: 48.6 ug/mL
Beside the measured number, compound 3's estimate is 3.5-fold (0.54 log units) below it, and the stated range ends below it.
By their numbers in this assay, from the lowest: compound 2; then compounds 1 and 3 (each within the scatter of the next).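

In this assay the effect at this aromatic carbon proves not to be general to any group placed there: iodo in place of methyl gives a 3.2-fold higher number from compound 2 to compound 3 (0.50 log units; beyond the scatter) and iodo in place of hydrogen gives a 1.0-fold higher number from compound 1 to compound 3 (0.01 log units; within the scatter). Among the three compounds, only the methyl of compound 2 stands apart, while iodo and hydrogen cannot be told apart. Nothing available explains this difference. As far as these compounds go, whether a chloro, a methoxy or an amine at this carbon would follow methyl or iodo remains open.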